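Swapping the benzyl aryl group on a shared diaminoquinoxaline core

A few compounds are considered here, and "the series" means these few. Any claim that something is new, unique, unknown or untested is made for them only; others in the source may bear on it.

Of the compounds shown here, two have been tested in a functional assay on RXF 393 cells (Homo sapiens) for inhibition, read by sulforhodamine B assay, with a stated time of 48 h (on this read-out higher numbers stand for lower toxicity in this test and lower numbers for higher toxicity in this test), and both returned only a limit rather than a number. Compound 1, `CCOC(=O)[C@H](CCC(=O)O)NC(=O)c1ccc(CNc2nc3cc(N)cc(N)c3nc2-c2ccccc2)cc1`, carries a glutamate-type side chain on its benzamide; in this assay compound 1 gives < 100000 nM, which is a limit of the assay. Compound 2, `Nc1cc(N)c2nc(-c3ccccc3)c(NCc3ccc(Cl)c(Cl)c3)nc2c1`, replaces that side chain with a 3,4-dichlorobenzyl group on the ring nitrogen; in this assay compound 2 gives < 100000 nM, again a limit of the assay and not a measured number. So compound 2 stands where every value in this set stands, as the limit of < 100000 nM in this assay, at which 2 of the 2 values shown sit, shows, and no ordering among the compounds can be drawn from these results.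

Compound 3, `COc1ccc(CNc2nc3cc(N)cc(N)c3nc2-c2ccccc2)cc1`, differs from compound 2 by 4-methoxyphenyl in place of 3,4-dichlorophenyl on a saturated chain carbon bound to a nitrogen on an aromatic ring. Going by the values given here, no measured step speaks to such a change, so the expectation rests only on the two limits shared by compound 1 and compound 2. The step from compound 2 to compound 3 in this assay is expected to be a step that the limit leaves unreadable from compound 2 to compound 3, that is, nothing beyond the usual scatter. For compound 3 the estimated result in this assay is 50000 nM, with a likely range from 10000 nM to 100000 nM, and there is a fair chance that the assay once more reports only a limit.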

Compound 3, concentration lethal to 50% of the cells: 44700 nM
Compound 3: the middle estimate sits 1.1-fold (0.05 log units) above what was measured, within the range that was stated.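

No step can be read between compound 2 and compound 3: compound 2 has only a limit of the assay, and the change from 3,4-dichlorobenzyl to 4-methoxybenzyl has no size that can be stated. The compounds shown leave open whether swapping the benzyl aryl group changes the read-out at all, with no two of them both carrying a measured number.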